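Swapping the Aryl Amide Group for a Pyridyl Amide

The source may hold more compounds than are shown below. What is called first, only, known or untested is meant among the compounds shown, and "the series" means these compounds.

Compound 1 `CC(C)(C)C(=O)N1CCCn2nc(COc3ccccc3)cc21` carries a tert-butyl group on the carbonyl carbon of its amide. In a functional assay on HEK293 cells for positive allosteric modulation of metabotropic glutamate receptor 5 (Homo sapiens), read by calcium flux (on this read-out lower numbers stand for smaller maximal responses and higher numbers for larger maximal responses), compound 1 gives 64%. Compound 2 `O=C(c1ccccc1F)N1CCCn2nc(COc3ccccc3)cc21` has a 2-fluorophenyl group in that place, and in this assay compound 2 gives 62%. The step of a number 2 percentage points lower from compound 1 to compound 2 (within the scatter) shows that both numbers lie within the scatter of each other, so the two compounds cannot be told apart on this read-out.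

Compound 3 `O=C(c1ccncc1)N1CCCn2nc(COc3ccccc3)cc21` differs from compound 2 in one place: pyridin-4-yl in place of 2-fluorophenyl on a carbonyl carbon. Among the measured compounds shown here, the only measured step that bears on this change is the one that also replaced the group on the same carbonyl carbon, a number 2 percentage points lower from compound 1 to compound 2 (within the scatter), and it stayed within the scatter. On that basis no step beyond the scatter is expected in this assay for the new exchange either, in neither direction.

Compound 3 is therefore estimated to give 62% in this assay, with a range from 48% to 76%. The expected step of no change at the digits printed from compound 2 to compound 3 (within the scatter) is thus estimated to remain within the usual scatter.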

Compound 3, largest response reached (reported as percent of maximum), in percent of the reference or control that the assay uses: 51%
Estimate against measurement, compound 3: 11 percentage points above; the range from low to high includes it.
By their numbers in this assay, from the lowest: compound 3; then compounds 2 and 1 (each within the scatter of the next).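

The carbonyl carbon, where the exchange of tert-butyl for 2-fluorophenyl moved nothing beyond the scatter, proves able to shift the maximal response in this assay: pyridin-4-yl in place of 2-fluorophenyl gives a number 11 percentage points lower from compound 2 to compound 3 (beyond the scatter), and pyridin-4-yl in place of tert-butyl gives a number 13 percentage points lower from compound 1 to compound 3 (beyond the scatter), so the same outcome is reached from either earlier group. The exchange from 2-fluorophenyl brings in a ring nitrogen, counted as a hydrogen-bond acceptor, and removes the fluorine in one move, so this single step cannot divide the lower number between those two differences. Nothing available here accounts for the lower number in terms of a measured property of the group.

The compounds shown leave open whether the result belongs to the ring nitrogen as such or to where it sits in the ring, which pyridin-3-yl or pyridin-2-yl on the same carbonyl carbon would address, and whether plain phenyl would stay level with compound 2 or fall toward compound 3. They also leave open how a saturated ring such as morpholine or a simple amine on that carbonyl carbon would read in this assay.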